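This account rests on a few compounds, and the source may have more. Where it says the series, first, only, none or still open, it means among the compounds named here.

Working notes on the series around the shared core of compound 2 `CCOC(=O)CCCCCOc1cccc(CN(C(=O)c2ccc(-c3cccc(OC)c3)cc2)C(C)C)c1`, followed in an ADME assay on HEK293 cells (Homo sapiens) for cytotoxicity, read by CellTiter-Glo and resazurin assay, with a stated time of 72 h; on this read-out lower numbers stand for an effect already at smaller amounts and higher numbers for an effect only at larger amounts of compound. Compound 1 `CCOC(=O)CCCCCOc1cccc(CN(C(=O)c2ccc(-c3cccc(OC(C)C)c3)cc2)C(C)C)c1` gives only a limit there, > 26000 nM. Compound 2 likewise gives only a limit, > 21000 nM. The step that the two limits leave unreadable from compound 1 to compound 2 therefore cannot be read from these two values. Compound 3 `CCOC(=O)CCCCCOc1cccc(CN(C(=O)c2ccc(-c3ccc4[nH]ccc4c3)cc2)C(C)C)c1` differs from compound 2 by 1H-indol-5-yl in place of 3-methoxyphenyl on an aromatic carbon. Within the data shown here, the only measured step that bears on a change at this position is the unreadable one between the first two compounds; neither the limit of > 21000 nM in this assay, at which 1 of the 2 values shown sits, nor the limit of > 26000 nM in this assay, at which 1 of the 2 values shown sits, yields a number, and no measured size of a change at this position is known. For compound 3 no step beyond the scatter is expected, and the estimated step that the limit leaves unreadable from compound 2 to compound 3 is set close to no change. Compound 3 is therefore expected to give 28000 nM in this assay, within 12000 nM to 60000 nM, most probably again reported only as a limit.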

Compound 3, half-maximal effective concentration: > 26000 nM
Compound 3 gave a limit, no number (the forecaster's own chance of this, stated with the estimate: 75%); the middle value does not contradict the limit.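

In this assay, among these compounds, compound 1, compound 2 and compound 3 all give only limits and no numbers, so no step among them can be read. Still open, as far as these compounds go, is whether replacing the aryl group on the shared core changes the half-maximal effective concentration at all, and by how much.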